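Lengthening the open-chain group of compound 3

This account rests on a few compounds, and the source may have more. Where it says the series, first, only, none or still open, it means among the compounds named here.

Among the measured compounds shown here, compound 3 `CO/N=C(\C)c1ccccc1NCC1=NCCN1` gives 20.9 nM in a functional assay for activation of Alpha-1A adrenergic receptor (Homo sapiens), read by calcium flux (a lower number here means that less compound is needed, a higher number that more compound is needed for the effect), the second highest of the three numbers known. Its nearest neighbour is compound 2 `c1ccc(-c2ccccc2NCC2=NCCN2)nc1`, which gives 6.76 nM in this assay. That gap is a 3.1-fold higher number from compound 2 to compound 3 (0.49 log units; beyond the scatter). Furthest from it lies compound 1 `Cc1noc(-c2ccccc2NCC2=NCCN2)n1`, which gives 661 nM in this assay. The corresponding step is a 32-fold lower number from compound 1 to compound 3 (1.50 log units; beyond the scatter), and between the two ring-bearing compounds it is a 98-fold lower number from compound 1 to compound 2 (1.99 log units; beyond the scatter).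

Compound 4 `CC/C(=N/OC)c1ccccc1NCC1=NCCN1` differs from compound 3 by a group of 6 heavy atoms (4 carbon, 1 nitrogen, 1 oxygen; no ring) in place of a group of 5 heavy atoms (3 carbon, 1 nitrogen, 1 oxygen; no ring), on an aromatic carbon. For the measured compounds named here, no measured pair shows a change of this kind. Going by the values given here, the three known steps all exchange the entire group on that aromatic carbon for an aromatic ring or the reverse, and they establish only that the open-chain group of compound 3 is well tolerated compared with compound 1. Nothing among them bears on extending that group, so no step beyond the scatter is expected in this assay, in either direction.

The estimate for compound 4 in this assay is 25 nM, with a range of 10 nM to 65 nM. The expected step of a 1.2-fold higher number from compound 3 to compound 4 (0.08 log units; within the scatter) is taken to stay within the scatter.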

Compound 4, half-maximal effective concentration: 87.1 nM
Compound 4: middle estimate off by 3.5-fold (0.54 log units), on the low side; measured number above the stated range.
By their numbers in this assay, from the lowest: compound 2; then compound 3; then compound 4; then compound 1.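

In this assay, the open-chain group on this aromatic carbon proves sensitive to its own size: going from the group of 5 heavy atoms to the group of 6 heavy atoms, with one carbon more and the same hydrogen-bond donor and acceptor counts, costs more than the scatter (a 4.2-fold higher number from compound 3 to compound 4 (0.62 log units; beyond the scatter)). The larger open-chain group falls further behind pyridin-2-yl (a 13-fold higher number from compound 2 to compound 4 (1.11 log units; beyond the scatter)) and keeps a smaller lead over 3-methyl-1,2,4-oxadiazol-5-yl (a 7.6-fold lower number from compound 1 to compound 4 (0.88 log units; beyond the scatter)), so the earlier tolerance of compound 3 does not carry over to compound 4. No supporting data bear on what lies behind this step.

On these data alone, whether a longer chain on this carbon would raise the number further remains open. So does the standing of an amine or a carboxylic acid at the same place.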